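Chlorine for methyl on the benzylamide of compound 3

This account rests on a few compounds, and the source may have more. Where it says the series, first, only, none or still open, it means among the compounds named here.

Measured so far in an assay on microsomes from liver for inhibition of 3-hydroxy-3-methylglutaryl-coenzyme A reductase (Rattus norvegicus); a higher number here means a weaker inhibitor, a lower number a stronger inhibitor:
compound 1 `Cc1ccc(CNC(=O)c2nn(-c3ccc(F)cc3)c(CC[C@@H](O)C[C@@H](O)CC(=O)O)c2C(C)C)cc1` gives 2.5 nM
compound 2 `CC(C)c1c(C(=O)N2CCC[C@H](N3CCC4C=CC=CC4C3)C2)nn(-c2ccc(F)cc2)c1CC[C@@H](O)C[C@@H](O)CC(=O)O` gives 10 nM
compound 3 `Cc1cccc(CNC(=O)c2nn(-c3ccc(F)cc3)c(OC[C@@H](O)C[C@@H](O)CC(=O)O)c2C(C)C)c1` gives 4.9 nM

Compound 3 has the second highest of the three numbers in this assay. Its nearest neighbour is compound 1, whose number is lower, but the gap between them lies within the usual scatter, so the two cannot be placed in order. Compound 2 stands furthest away, with a higher number than compound 3, and that gap lies beyond the scatter.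

Compound 4 `CC(C)c1c(C(=O)NCc2ccc(Cl)cc2)nn(-c2ccc(F)cc2)c1OC[C@@H](O)C[C@@H](O)CC(=O)O` has not yet been measured. It differs from compound 3 in one place: 4-chlorophenyl in place of 3-methylphenyl on a saturated chain carbon bound to an amide-type nitrogen. The rest of the molecule, including the shared core and the dihydroxy acid chain, is unchanged.

Going by the values given here, no pair of measured compounds differs in one place only, so there is no measured step to lean on. The change swaps one group of seven heavy atoms for another of the same size, with no change in donors, acceptors or charge. The step from compound 3 to compound 4 in this assay is expected to be small, with no direction beyond the scatter, as a 1.1-fold lower number from compound 3 to compound 4 (0.04 log units; within the scatter) expresses. Compound 4 is therefore estimated at 4.5 nM, within a range from 2 nM to 10 nM.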

Compound 4, half-maximal inhibitory concentration: 6.7 nM
Estimate against measurement, compound 4: 1.5-fold (0.17 log units) below, within the range that was stated.
By their numbers in this assay, from the lowest: compounds 1, 3, 4 and 2 (each within the scatter of the next, the first and the last beyond it).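

In this assay, going by these compounds alone, a 1.4-fold higher number from compound 3 to compound 4 (0.14 log units; within the scatter) is the first step read at this position, and it leaves compound 3 and compound 4 in no order, so the 4-chlorophenyl and 3-methylphenyl groups on a saturated chain carbon bound to an amide-type nitrogen cannot be told apart here. Within the data shown here, this is something the earlier compounds could not show, as no two of them differed in one place only. The step exchanges methyl for chlorine and also changes the number in the group's name, so this one comparison cannot assign any share of it to either difference, and nothing measured here accounts for it.

What the compounds shown leave open is how a 3-chlorophenyl group at this place would compare, a group that would separate the exchange of methyl for chlorine from the other difference, and whether a phenyl ring bearing an amine or a carboxylic acid would stay within the scatter of compound 3. Also open, from the compounds shown here alone, is how a longer chain in place of the saturated carbon bound to the amide-type nitrogen would read in this assay.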